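The compounds below may be only part of what the source reports. "The series", "measured", "known", "first", "only" and "open" are said of these compounds alone.

Compound 1 `CC(C(=O)NCc1ccc(C(F)(F)F)nc1NC1CCCCC1)c1ccc(NS(C)(=O)=O)c(F)c1` serves as the reference point. In a functional assay on CHO-K1 cells for antagonist activity at transient receptor potential cation channel subfamily V member 1 (Homo sapiens), read by FLIPR (a lower number here means a stronger inhibitor, a higher number a weaker inhibitor), compound 1 gives 260 nM, the highest of the two numbers obtained so far. Compound 2 `CC(C(=O)NCc1ccc(C(F)(F)F)nc1NCc1cccnc1)c1ccc(NS(C)(=O)=O)c(F)c1` is recorded in this assay as "not active" (no number reported), so it adds no number. Compound 3 `CCCCN(C)c1nc(C(F)(F)F)ccc1CNC(=O)C(C)c1ccc(NS(C)(=O)=O)c(F)c1` gives 21.3 nM in this assay. Within the data shown here, the only step with a number is a 12-fold lower number from compound 1 to compound 3 (1.09 log units; beyond the scatter), which came with butyl(methyl)amino in place of cyclohexylamino on an aromatic carbon.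

Compound 4 `CC(C(=O)NCc1ccc(C(F)(F)F)nc1N1CCC(C)(C)CC1)c1ccc(NS(C)(=O)=O)c(F)c1` carries the change (4,4-dimethylpiperidin-1-yl in place of cyclohexylamino on an aromatic carbon). This bears directly on the step to compound 3: both changes remove the same cyclohexylamino, and in both the entering group brings 0 hydrogen-bond donors where cyclohexylamino had 1. The step to compound 3 was large, but it is a single observation and the entering group here is a ring rather than a chain, so a lower number than compound 1 is expected for compound 4, beyond the scatter yet smaller than a 12-fold lower number from compound 1 to compound 3 (1.09 log units; beyond the scatter); the expected step is a 4.0-fold lower number from compound 1 to compound 4 (0.60 log units; beyond the scatter). Compound 4 is estimated at 65 nM, within 20 nM to 200 nM.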

Compound 4, half-maximal inhibitory concentration: 8 nM
Beside the measured number, compound 4's estimate is 8.1-fold (0.91 log units) above it, and the stated range ends above it.
By their numbers in this assay, from the lowest: compound 4; then compound 3; then compound 1.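

In this assay, 4,4-dimethylpiperidin-1-yl in place of cyclohexylamino on this aromatic carbon gives a 33-fold lower number from compound 1 to compound 4 (1.51 log units; beyond the scatter), so a second group with 0 hydrogen-bond donors now goes with a lower number, and the drop seen with butyl(methyl)amino no longer stands alone. The ring does not fall short of the chain: there is a 2.7-fold lower number from compound 3 to compound 4 (0.43 log units; beyond the scatter), a modest step but beyond the scatter, so an open chain is not required at this position. No measurement on these compounds accounts for either step.

Open, on these data alone, is how much of the step rests on the two methyl groups, which a plain piperidin-1-yl would separate from the ring itself. Also open, as far as these compounds go, is whether a morpholin-4-yl ring, with its oxygen, or a smaller dimethylamino group holds the number at this carbon.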